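The source may hold more compounds than are shown below. What is called first, only, known or untested is meant among the compounds shown, and "the series" means these compounds.

Of the compounds shown here, three built on a shared core have been tested in a functional assay on MDA-MB-231 cells (Homo sapiens) for cytotoxicity, read by MTT assay, with a stated time of 48 h, in the absence of a further agent; a lower number here means a stronger inhibitor, a higher number a weaker inhibitor. Compound 1 `COc1ccc2[nH]cc(-c3nc(C(=O)Nc4cc(OC)c(OC)c(OC)c4)cs3)c2c1` gives > 100000 nM, which is a limit of the assay rather than a number. Compound 2 `COc1cc(NC(=O)c2csc(-c3c[nH]c4ccc(Br)cc34)n2)cc(OC)c1OC` likewise gives > 100000 nM, again a limit. The step that the two limits leave unreadable from compound 1 to compound 2 is therefore unreadable. Compound 3 `O=C(Nc1ccccc1)c1csc(-c2cn(Cc3ccc(Cl)cc3)c3ccccc23)n1` is the only one to return a measured number: in this assay compound 3 gives 50500 nM. Among the measured compounds shown here, that is where compound 3 stands: the sole value, with the two other results sitting at the limit (the limit of > 100000 nM in this assay, at which 2 of the 3 values shown sit).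

Compound 4 `COc1cc(NC(=O)c2csc(-c3cn(Cc4ccc(Cl)cc4)c4ccccc34)n2)cc(OC)c1OC` differs from compound 3 in one place: 3,4,5-trimethoxyphenyl in place of phenyl on an amide-type nitrogen. For the measured compounds named here, no measured step follows exactly this change; compounds 1 and 2 carry the 3,4,5-trimethoxyphenyl too, but each differs from compound 4 in other places as well, so their values show only that compounds bearing that group have so far returned limits. The step of a 1.4-fold higher number from compound 3 to compound 4 (0.14 log units; within the scatter) is therefore expected to be small or to lean toward weaker inhibition, within or near the scatter. For compound 4 a value of about 70000 nM is estimated, in the range 25000 nM to 200000 nM, with a fair chance that only a limit is reported.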

Compound 4, half-maximal inhibitory concentration: > 100000 nM
Compound 4 ended at the assay's limit; the forecaster's own chance of this, stated with the estimate: 40%; at least 1.4-fold (0.15 log units) between middle value and limit.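

In this assay, the change on the amide-type nitrogen can now be read on its own, with nothing else in the structure altered, and it gives an at least 1.9-fold higher number from compound 3 to compound 4 (0.29 log units; that floor lies within the scatter). Compound 4 returned a limit and not a number, so that figure is only a floor on the step, and the floor alone does not separate the pair beyond the usual scatter. All the compounds shown with 3,4,5-trimethoxyphenyl now stand at the same limit, and the only measured number belongs to compound 3, which carries phenyl: the limit of > 100000 nM in this assay, at which 3 of the 4 values shown sit.

From the compounds shown here alone, it remains open whether a phenyl bearing a single methoxy, an amine or a carboxylic acid on the amide-type nitrogen would return a measured number. Going by these compounds, how far the true value of compound 4 lies past its limit also stays unknown.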